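Methoxy for fluoro on the benzyl arm

A few compounds are considered here, and "the series" means these few. Any claim that something is new, unique, unknown or untested is made for them only; others in the source may bear on it.

Three measured compounds frame the series in an assay on CHO cells for displacement of a labelled ligand from D(4) dopamine receptor (Homo sapiens), read by radioligand binding; a lower number here means a stronger inhibitor, a higher number a weaker inhibitor. Compound 1 `COc1ccccc1N1CCN(CCCNC(=O)/N=N/c2ccc(F)cc2)CC1` gives 20 nM. Compound 2 `COc1ccccc1N1CCN(CCCCNC(=O)NN(Cc2ccccc2)c2ccc(F)cc2)CC1` gives 4.4 nM. Compound 3 `COc1ccccc1N1CCN(CCCNC(=O)NN(Cc2cccc(F)c2)c2ccc(F)cc2)CC1` gives 3.8 nM, which sits with compound 2 inside the scatter and a clear step below compound 1. Compound 4 `COc1cccc(CN(NC(=O)NCCCN2CCN(c3ccccc3OC)CC2)c2ccc(F)cc2)c1` is not yet measured; it differs from compound 3 by methoxy in place of fluoro on an aromatic carbon. For the measured compounds named here, no measured pair shows this kind of exchange, so nothing beyond the closeness of compounds 2 and 3 guides the expectation. In this assay the expected step is small, a 1.3-fold higher number from compound 3 to compound 4 (0.12 log units; within the scatter), with no direction that would exceed the scatter. Compound 4 is therefore estimated at 5 nM, with a range from 2 nM to 15 nM.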

Compound 4, inhibition constant: 5.9 nM
Compound 4: middle estimate off by 1.2-fold (0.07 log units), on the low side, and the stated range covers the measured number.
By their numbers in this assay, from the lowest: compounds 3, 2 and 4 (each within the scatter of the next); then compound 1.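

For the compounds shown here, the exchange of 3-fluorobenzyl for 3-methoxybenzyl gives a 1.6-fold higher number from compound 3 to compound 4 (0.19 log units; within the scatter) in this assay and supplies the first reading of this change. At this place, meta to a large group, methoxy brings one more heavy atom and one hydrogen-bond acceptor, yet the step stays within the scatter. No available evidence bears on this result.

Still open, going by these compounds, is how an amine or a carboxylic acid at this place would read. A longer chain in place of the methoxy is also untested by the compounds shown.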